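Hydroxy to dimethylamino on the aryl ring: compound 4

A few compounds are considered here, and "the series" means these few. Any claim that something is new, unique, unknown or untested is made for them only; others in the source may bear on it.

Among the measured compounds shown here, compound 1 `O=C1/C(=C\c2ccc(O)cc2)c2ccccc2N1c1c(Cl)cccc1Cl` gives 20 ug/mL in a functional assay on MCF7 cells (Homo sapiens) for cytotoxicity, read by MTT assay, with a stated time of 72 h (on this read-out lower numbers stand for an effect already at smaller amounts and higher numbers for an effect only at larger amounts of compound), the higher of the two numbers read so far; compound 3 `COc1ccc(/C=C2\C(=O)N(c3c(Cl)cccc3Cl)c3ccccc32)cc1OC` gives 10 ug/mL, which lies within the scatter of compound 1. For compound 2 `COc1ccc(/C=C2\C(=O)N(c3c(Cl)cccc3Cl)c3ccccc32)cc1` this assay reports only a limit, > 100 ug/mL. The measured steps are an at least 5.0-fold higher number from compound 1 to compound 2 (0.69 log units; beyond the scatter) and an at least 10-fold lower number from compound 2 to compound 3 (1.00 log units; beyond the scatter); the first rests on (the limit of > 100 ug/mL in this assay, at which 1 of the 3 values shown sits), so its true size is not fixed.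

Compound 4 `CN(C)c1ccc(/C=C2\C(=O)N(c3c(Cl)cccc3Cl)c3ccccc32)cc1` arises from compound 1 by dimethylamino in place of hydroxy on an aromatic carbon. The step from compound 1 to compound 2 bears on it, since there too the hydroxy donor is lost, and dimethylamino likewise carries no donor; that step was at least modest toward a higher number. For the measured compounds named here, no measured pair contains dimethylamino, so the transfer is uncertain. For compound 4 a step toward a higher number is expected, a 2.3-fold higher number from compound 1 to compound 4 (0.35 log units; beyond the scatter). Compound 4 is therefore estimated at 45 ug/mL, within 12 ug/mL to 150 ug/mL, with a fair chance that this assay reports only a limit.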

Compound 4, concentration for half-maximal effect: > 100 ug/mL
Compound 4 was reported as a limit (the forecaster's own chance of this, stated with the estimate: 30%); middle value at least 2.2-fold (0.34 log units) away from the limit.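

In this assay dimethylamino in place of hydroxy gives an at least 5.0-fold higher number from compound 1 to compound 4 (0.69 log units; beyond the scatter) and so adds a second group on this aromatic carbon, after the methoxy of compound 2, that ends in a limit and not a number. Loss of hydroxy alone does not settle the matter: compound 3 gives 10 ug/mL with a second methoxy on the ring. The step between compound 2 and compound 4 cannot be read, and the true size of the step from compound 1 stays unfixed, because both rest on a limit: the limit of > 100 ug/mL in this assay, at which 2 of the 4 values shown sit.

Open, going by these compounds, is whether a primary amine or a carboxylic acid on this carbon would give a number or a limit. Also open, on these data alone, is how far compound 2 and compound 4 lie from each other.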